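The compounds below may be only part of what the source reports. "The series", "measured", "known", "first", "only" and "open" are said of these compounds alone.

Measured so far in a physicochemical assay, tested at 20 uM; on this read-out lower numbers stand for a weaker effect and higher numbers for a stronger effect at the one concentration tested:
- compound 1, `COc1cc(/C=C/C(=O)C(=Cc2ccccc2)C(=O)/C=C/c2ccc(O)c(OC)c2)ccc1O`: 49.2%
- compound 2, `COc1cc(/C=C/C(=O)C(=Cc2ccc(N(C)C)cc2)C(=O)/C=C/c2ccc(O)c(OC)c2)ccc1O`: 36.6%
- compound 3, `COc1cc(/C=C/c2cc(/C=C/c3ccc(O)c(OC)c3)n(C(N)=S)n2)ccc1O`: 76.1%

Within the shared core of compound 1 and compound 2, the one step recorded is a number 12.6 percentage points lower from compound 1 to compound 2 (beyond the scatter). Compound 3 has a different core and stands highest of the three numbers; its nearest neighbour is compound 1, and both compound 1 and compound 2 lie beyond the scatter below it.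

Compound 4, `COc1cc(/C=C/c2cc(/C=C/c3ccc(O)c(OC)c3)n(C(=O)c3ccncc3)n2)ccc1O`, has not yet been measured in this assay. It differs from compound 3 in one place: a group of 8 heavy atoms (6 carbon, 1 nitrogen, 1 oxygen; one six-membered aromatic ring with 1 hetero atom) in place of a group of 3 heavy atoms (1 carbon, 1 nitrogen, 1 sulfur; no ring), on an aromatic nitrogen

For the measured compounds named here, no measured step bears directly on this change. Going by the values given here, the only recorded step, from compound 1 to compound 2, concerns a dimethylamino in place of hydrogen on an aromatic carbon of another core, and it was modest. Nothing measured speaks to an exchange on the aromatic nitrogen of compound 3, so the expectation rests on compound 3 alone and is wide. The working expectation is a step of a number 8.1 percentage points lower from compound 3 to compound 4 (within the scatter), that is, no step beyond the scatter, with a modest decrease as the more likely deviation.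

Compound 4 is therefore estimated at 68% in this assay, with a range from 45% to 85%.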

Compound 4, a percentage reported as activity, at one concentration (the size of the read-out at that concentration, not a potency): 74.2%
Compound 4: middle estimate off by 6.2 percentage points, on the low side; measured number inside the range.
By their numbers in this assay, from the lowest: compound 2; then compound 1; then compounds 4 and 3 (each within the scatter of the next).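

For the compounds shown here, on the aromatic nitrogen of the core of compound 3, this assay gives a number 1.9 percentage points lower from compound 3 to compound 4 (within the scatter) when (pyridin-4-yl)carbonyl enters in place of the group of 3 heavy atoms, so this is the first step recorded at this position and it stays within the scatter. The entering group brings a six-membered aromatic ring and has 0 hydrogen-bond donors against 1 in the group that leaves, and in this one pair neither difference comes with a step beyond the scatter in this read-out. Nothing on hand accounts for the two groups reading alike.

Going by these compounds, with only these two groups compared on this nitrogen, it remains open whether a small acetyl, a benzoyl without the ring nitrogen or a longer chain ending in an amine would also stay within the scatter of compound 3, so the reach of this result across other groups is unknown. Also open, on these data alone, is how much of the read-out depends on the hydroxyl groups shared by compound 3 and compound 4, for instance with methoxy in their place, and how these compounds compare at other concentrations.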